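The source may hold more compounds than are shown below. What is called first, only, known or untested is meant among the compounds shown, and "the series" means these compounds.

Compound 1 `O=C(Nc1ccc(Oc2ccnc3[nH]ccc23)cc1)c1cc2cccnc2n(-c2ccccc2)c1=O` is the anchor of this small series. Among the compounds with values here, in a functional assay on U-87MG ATCC cells for antiproliferative activity against U-87 MG (Homo sapiens), read by MTT assay, with a stated time of 72 h (on this read-out higher numbers stand for weaker inhibition and lower numbers for stronger inhibition), compound 1 gives 1580 nM, and that is the only number in hand: compound 2 `O=C(Nc1ccc(Oc2ccnc3[nH]ccc23)cc1)c1cc2cccnc2n(-c2ccc(Br)cc2)c1=O`, which carries a bromine on the phenyl attached to the shared core, has in this assay the entry "not determined" (no result reported), so no comparison between these two can be drawn. Compound 3 `O=C(Nc1ccc(Oc2ccnc3[nH]ccc23)c(F)c1)c1cc2cccnc2n(-c2ccccc2)c1=O` differs from compound 1 by a single substitution on the aniline-bearing ring: fluoro in place of hydrogen on an aromatic carbon. Within the data shown here, no measured pair shows what such a change does here, so the expectation rests on the single value of compound 1 alone. The step from compound 1 to compound 3 is expected to be small, likely within the usual scatter, as a 1.3-fold lower number from compound 1 to compound 3 (0.12 log units; within the scatter) expresses. Compound 3 is therefore estimated to give about 1200 nM in this assay, with a plausible range from 400 nM to 4000 nM.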

Compound 3, half-maximal inhibitory concentration: 1260 nM
The estimate for compound 3 lay 1.1-fold (0.02 log units) below the measured number; the measured number falls inside the stated range.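

In this assay, within the data shown here, the series gains its one readable step, fluoro in place of hydrogen on an aromatic carbon, ortho to a large group and meta to a large group (a 1.3-fold lower number from compound 1 to compound 3 (0.10 log units; within the scatter)). Among these compounds, the single value of compound 1 could not show how this position responds to substitution, whereas the step now shows that a fluoro group here leaves compound 3 indistinguishable from compound 1 on this read-out. Nothing in hand offers an explanation for this result.

The compounds shown leave open whether a methoxy group, an amine or a carboxylic acid at this same place would also leave the number within the scatter of compound 1. From the compounds shown here alone, the step to compound 2 cannot be read, so the effect of the bromine on the phenyl attached to the shared core remains open.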